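Replacing the phenyl of compound 1 with pyrrolidin-3-yl

The source may hold more compounds than are shown below. What is called first, only, known or untested is meant among the compounds shown, and "the series" means these compounds.

The three measured compounds share one core and differ only in the group attached to it. In a physicochemical assay for solubility, read by LC-MS, in phosphate buffer, measured as thermodynamic solubility, with a stated time of 24 h, at pH 7.4 (on this read-out lower numbers stand for lower solubility and higher numbers for higher solubility), compound 1 `Cn1cc(-c2cnc3[nH]cc(-c4ccccc4)c3c2)cn1` gives 20000 nM, the highest of the three numbers. Compound 3 `Cn1cc(-c2cnc3[nH]cc(-c4cncc(C#N)c4)c3c2)cn1` gives 17000 nM in this assay, which lies within the scatter of compound 1, so the two cannot be told apart. Among the compounds with values here, compound 2 `Cn1cc(-c2cnc3[nH]cc(-c4cccc(C(F)(F)F)c4)c3c2)cn1` gives 1000 nM in this assay; the one step that differs in a single place, a 20-fold lower number from compound 1 to compound 2 (1.30 log units; beyond the scatter), is large and goes downward.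

Compound 4 `Cn1cc(-c2cnc3[nH]cc(C4CCNC4)c3c2)cn1` is not yet measured in this assay. It differs from compound 1 as follows: pyrrolidin-3-yl in place of phenyl on an aromatic carbon. Within the data shown here, none of the measured steps bears directly on this change: the only step beyond the scatter concerns a trifluoromethyl added to the phenyl, a group that compound 4 does not carry, and compound 3 shows that swapping the aromatic ring for another six-membered aromatic ring left the number within the scatter of compound 1. The account therefore expects the step of a 3.5-fold higher number from compound 1 to compound 4 (0.54 log units; beyond the scatter) to be upward and beyond the scatter, though with wide uncertainty. Compound 4 is estimated at 70000 nM, with a range from 20000 nM to 250000 nM.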

Compound 4, solubility: 1000000 nM
Beside the measured number, compound 4's estimate is 14-fold (1.15 log units) below it; the whole stated range lies below it.
By their numbers in this assay, from the lowest: compound 2; then compounds 3 and 1 (each within the scatter of the next); then compound 4.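

Within the data shown here, putting pyrrolidin-3-yl in place of phenyl gives a 50-fold higher number from compound 1 to compound 4 (1.70 log units; beyond the scatter) in this assay, the first upward step beyond the scatter at this position, on an aromatic carbon of a five-membered aromatic ring with 1 nitrogen. The earlier compounds shown here showed only a large downward step with the trifluoromethyl on the phenyl and no separable difference with the nitrile-bearing ring of compound 3, so they gave no sign that a change here could raise the number, let alone by this much. This single change replaces a six-membered aromatic ring of carbon only with a five-membered non-aromatic ring with 1 hetero atom, and brings in a hydrogen-bond donor and acceptor, but nothing measured here separates these differences or explains the step.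

The compounds shown leave open whether the ring nitrogen or the loss of the aromatic ring accounts for the step, a question that a cyclopentyl group on the same aromatic carbon could address. They also leave open how the number would respond to a methyl or an acetyl on the pyrrolidine nitrogen, or to a piperidin-4-yl in place of the pyrrolidin-3-yl.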